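Swapping the Aryl on the Sulfonamide Nitrogen

This account rests on a few compounds, and the source may have more. Where it says the series, first, only, none or still open, it means among the compounds named here.

Of the compounds shown here, two have been tested in a functional assay on M21 cells (Homo sapiens) for antiproliferative activity, read by sulforhodamine B assay, with a stated time of 48 h; a higher number here means a weaker inhibitor, a lower number a stronger inhibitor. Compound 1 `O=C1NCCN1c1ccc(S(=O)(=O)Nc2ccc(F)c(F)c2)cc1` gives 220 nM, and compound 2 `O=C1NCCN1c1ccc(S(=O)(=O)Nc2ccc(Cl)cc2)cc1` gives 90 nM, the lowest of the two numbers. Within the data shown here, the only measured step, a 2.4-fold lower number from compound 1 to compound 2 (0.39 log units; beyond the scatter), is modest and is the sole guide to how the aryl on the sulfonamide nitrogen affects this assay. Compound 3 `COc1ccccc1NS(=O)(=O)c1ccc(N2CCNC2=O)cc1` differs from compound 2 in one place: 2-methoxyphenyl in place of 4-chlorophenyl on a sulfonamide nitrogen. Among the measured compounds shown here, no measured pair exchanges 4-chlorophenyl for 2-methoxyphenyl, so the data only show that one change of this aryl shifted this assay by a modest amount. Compound 3 is therefore expected to move by a similar modest amount, most likely toward a higher number, a step of a 2.2-fold higher number from compound 2 to compound 3 (0.35 log units; beyond the scatter). The estimate for compound 3 in this assay is 200 nM, within a range from 60 nM to 700 nM.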

Compound 3, half-maximal inhibitory concentration: 300 nM
The estimate for compound 3 lay 1.5-fold (0.18 log units) below the measured number; low and high end bracket the measured number.
By their numbers in this assay, from the lowest: compound 2; then compounds 1 and 3 (each within the scatter of the next).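

In this assay, 2-methoxyphenyl on the sulfonamide nitrogen gives a 3.3-fold higher number from compound 2 to compound 3 (0.52 log units; beyond the scatter) and so leaves the 4-chlorophenyl of compound 2 with the lowest number of the three, now beyond the scatter of both other compounds. Measured against 3,4-difluorophenyl, the same exchange gives a 1.4-fold higher number from compound 1 to compound 3 (0.13 log units; within the scatter) and so does not separate these two aryl groups, which leaves 4-chlorophenyl alone apart from them at this position. The compounds shown offer no evidence that explains these differences.

They leave open how 4-methoxyphenyl would compare with 4-chlorophenyl, as the step from compound 2 to compound 3 changes both the substituent and its place on the ring. On these data alone, it also remains open whether a pyridyl ring or a benzyl group on the same nitrogen would keep the number of compound 2.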